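This account rests on a few compounds, and the source may have more. Where it says the series, first, only, none or still open, it means among the compounds named here.

In a series of indole-based glyoxamides, two compounds have been tested in a functional assay on FaDu cells (Homo sapiens) for cytotoxicity, read by MTT assay, with a stated time of 72 h (on this read-out higher numbers stand for lower toxicity in this test and lower numbers for higher toxicity in this test), so far. Compound 1 `COc1nsc(NC(=O)C(=O)c2cn(C(C)C)c3ccccc23)n1` gives 10400 nM in this assay, and compound 2 `COc1ccc(NC(=O)C(=O)c2cn(C(C)C)c3cc(Cl)ccc23)cn1` gives 1770 nM in the same test. Among the compounds with values here, of the two numbers, compound 1 stands highest, with compound 2 the only other measured compound and lying well apart from it. Compounds 1 and 2 differ from each other in more than one place, so their two values can be compared only as a pair of readings and not as a single step.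

Compound 3 `CC(C)n1cc(C(=O)C(=O)Nc2cccnc2)c2ccccc21` has not yet been measured in this assay. It differs from compound 1 in one place: pyridin-3-yl in place of 3-methoxy-1,2,4-thiadiazol-5-yl on an amide-type nitrogen. Within the data shown here, since no single-change step between measured compounds is available here, any expectation for compound 3 must rest on the two readings alone. The estimate for compound 3 in this assay is 4000 nM, within a range from 800 nM to 20000 nM. The step this implies a 2.6-fold lower number from compound 1 to compound 3 (0.41 log units; beyond the scatter) is expected to run toward a lower number, of a size that may just exceed the scatter.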

Compound 3, concentration lethal to 50% of the cells: > 10000 nM
Compound 3 was reported as a limit; the forecaster's own chance of this, stated with the estimate: 10%; middle value at least 2.5-fold (0.39 log units) away from the limit.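

In this assay compound 3 gives > 10000 nM, which is a limit of the assay and not a number. No step from compound 1 to compound 3 can be read, because the result for compound 3 is set by a limit: the limit of > 10000 nM in this assay, at which 1 of the 3 values shown sits.

The compounds shown leave open how far, and in which direction, pyridin-3-yl in place of 3-methoxy-1,2,4-thiadiazol-5-yl on an amide-type nitrogen moves the number.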